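Benzylamino Replaces a Ring Amine in a Cell Assay

This account rests on a few compounds, and the source may have more. Where it says the series, first, only, none or still open, it means among the compounds named here.

Measured compounds:
compound 1, `CN(C)c1nc2c(ncn2-c2ccccc2)c(=O)n1-c1ccccc1`: > 100000 nM
compound 2, `O=c1c2ncn(-c3ccccc3)c2nc(N2CCCCC2)n1-c1ccc(Cl)cc1`: > 100000 nM

In a functional assay on HepG2 cells (Homo sapiens) for cytotoxicity, read by MTT assay, with a stated time of 72 h (on this read-out higher numbers stand for weaker inhibition and lower numbers for stronger inhibition), compound 1 gives > 100000 nM, and this is a limit of the assay rather than a number. Compound 2 gives > 100000 nM in this assay, which is again a limit and not a measured number. Both values shown therefore sit at the limit of > 100000 nM in this assay, at which 2 of the 2 values shown sit, so compound 2 stands where every compound shown so far stands: no number for it has been reached in this assay.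

Compound 3, `O=c1c2ncn(-c3ccccc3)c2nc(NCc2ccccc2)n1-c1ccc(Cl)cc1`, differs from compound 2 in one place: benzylamino in place of piperidin-1-yl on an aromatic carbon. Among the compounds with values here, no step between two measured compounds is available to set a scale for such a change. With compound 2 already at a limit, the expectation for compound 3 is that this assay will again return no number. The step from compound 2 to compound 3 that this expectation means is a step that the limit leaves unreadable from compound 2 to compound 3, which is expected to be none beyond the usual scatter. The estimated value for compound 3 is 150000 nM, with an expected range from 50000 nM to 500000 nM.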

Compound 3, half-maximal inhibitory concentration: 62100 nM
Compound 3: the middle estimate sits 2.4-fold (0.38 log units) above what was measured; low and high end bracket the measured number.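

Benzylamino in place of piperidin-1-yl, on the aromatic carbon between two ring nitrogen atoms, brings the first actual number of this series: in this assay, compound 3 gives 62100 nM. Read as a step, the change is an at least 1.6-fold lower number from compound 2 to compound 3 (0.20 log units; that floor lies within the scatter), so what can be stated from these values alone does not go beyond ordinary variation between repeated measurements. Compound 2 gives > 100000 nM, which is a limit and not a number, so the true step could be larger and only its floor can be given: the limit of > 100000 nM in this assay, at which 2 of the 3 values shown sit.

From the compounds shown here alone, what stays open is whether the measured number goes with the aromatic ring of benzylamino or with its hydrogen-bond donor, as both enter together in this single change. Cyclohexylmethylamino at the same carbon would keep the donor without the aromatic ring, and 2-phenylethylamino, with its longer chain, would test the distance between that ring and the core, but the compounds shown say nothing about either group.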